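Replacing fluoro with acetamido: an untested change

A few compounds are considered here, and "the series" means these few. Any claim that something is new, unique, unknown or untested is made for them only; others in the source may bear on it.

In a functional assay on QGY-7703 cells (Homo sapiens) for cytotoxicity, read by MTT assay, with a stated time of 24 h (a lower number here means a stronger inhibitor, a higher number a weaker inhibitor), compound 1 (`COc1cc(/C=C2\CN(S(=O)(=O)c3ccc(F)cc3)C/C(=C\c3ccc(C#N)cc3)C2=O)cc(OC)c1OC`) gives 4980 nM and compound 2 (`COc1cc(/C=C2\CN(S(=O)(=O)c3ccc(F)cc3)C/C(=C\c3cc(OC)c(OC)c(OC)c3)C2=O)cc(OC)c1`) gives 5200 nM in the same test. The two numbers are within the scatter of repeated measurements (a 1.0-fold higher number from compound 1 to compound 2 (0.02 log units; within the scatter)), so compound 2 stands level with compound 1.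

Compound 3 (`COc1cc(/C=C2\CN(S(=O)(=O)c3ccc(NC(C)=O)cc3)C/C(=C\c3cc(OC)c(OC)c(OC)c3)C2=O)cc(OC)c1`) is not yet measured. It carries acetamido in place of fluoro on an aromatic carbon, para to a large group (acetamido in place of fluoro on an aromatic carbon). Among the measured compounds shown here, the one measured step (a 1.0-fold higher number from compound 1 to compound 2 (0.02 log units; within the scatter)) is small, but it replaced a different group, with 4-fluorophenyl present on both sides. It therefore shows only that this series has tolerated one other swap, and it gives no direct reading on the new change. With no measured evidence for a direction, no shift beyond the scatter is expected in this assay, and the expected step is small (a 1.0-fold lower number from compound 2 to compound 3 (0.02 log units; within the scatter)). For compound 3 the estimated value is 5000 nM with an expected range from 1800 nM to 14000 nM in this test. For the measured compounds named here, the range is kept wide, as no measured compound varies the fluoro group.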

Compound 3, half-maximal inhibitory concentration: 2020 nM
For compound 3 the middle estimate is 2.5-fold (0.39 log units) above the measured one; measured number inside the range.
By their numbers in this assay, from the lowest: compound 3; then compounds 1 and 2 (each within the scatter of the next).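

In this assay, among the compounds shown here, the step of a 2.6-fold lower number from compound 2 to compound 3 (0.41 log units; beyond the scatter) is the first change in this small set to go beyond the scatter, whereas the swap at the other place, a 1.0-fold higher number from compound 1 to compound 2 (0.02 log units; within the scatter), did not. So the aromatic carbon para to a large group is a place where a change can move the number, and the move here is modest and toward a stronger inhibitor. It also shows that this place accepts acetamido, with its 4 heavy atoms, in place of the single fluorine atom without any loss in this test, although no measurement shown bears on what lies behind the step.

As far as these compounds go, this remains a single replacement at this place, read against one partner group, so it is open whether the same swap would give a similar step in the compound carrying 4-cyanophenyl. From the compounds shown here alone, it is also open which part of acetamido matters: a plain amine at this place, or a longer chain such as propionamido, would begin to separate the contribution of the amide hydrogen and carbonyl from that of the methyl end.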